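Working notes: cyclopropyl to cyclohexyl in compound 3

The source may report more compounds than this note shows. Statements on the series, on what has been measured and on what is new or still open speak of the compounds shown alone.

Measured in an ADME assay on microsomes from liver (Homo sapiens) for metabolic stability, with a stated time of 10 min; on this read-out higher numbers stand for a more stable compound and lower numbers for a less stable compound:
compound 1 `Cc1cccc(C)c1COC(c1ccc([C@]2(S(=O)(=O)c3ccc(F)cc3)CCN(C(=O)[C@H]3CC[C@H](C(=O)O)CC3)C2)cc1)(C(F)(F)F)C(F)(F)F` gives 89%
compound 2 `O=C(O)[C@H]1CC[C@H](C(=O)N2CC[C@](c3ccc(C(OCC4CC4)(C(F)(F)F)C(F)(F)F)cc3)(S(=O)(=O)c3ccc(F)cc3)C2)CC1` gives 75%

Of these two, compound 2 stands lowest at 75%. Compound 3 `O=C(O)[C@H]1CC[C@H](C(=O)N2CC[C@](c3ccc(C(OCC4CCCCC4)(C(F)(F)F)C(F)(F)F)cc3)(S(=O)(=O)c3ccc(F)cc3)C2)CC1` carries cyclohexyl in place of cyclopropyl on a saturated chain carbon bound to an oxygen on a saturated carbon. For the measured compounds named here, only one measured step bears on this place, a number 14 percentage points lower from compound 1 to compound 2 (beyond the scatter), and it is modest. No cyclohexyl has been measured there, so the direction rests on little. In this assay a small downward step, within the scatter, is expected. The expected step is a number 5 percentage points lower from compound 2 to compound 3 (within the scatter). For compound 3 the estimate is 70%, with an expected range of 50% to 86%.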

Compound 3, percent of the compound remaining: 92%
Beside the measured number, compound 3's estimate is 22 percentage points below it; the measured number lies above the stated range.
By their numbers in this assay, from the lowest: compound 2; then compounds 1 and 3 (each within the scatter of the next).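

In this assay, an aromatic ring is not required at this place, on a saturated chain carbon bound to an oxygen on a saturated carbon: cyclohexyl in place of cyclopropyl gives a number 17 percentage points higher from compound 2 to compound 3 (beyond the scatter). Cyclohexyl in place of 2,6-dimethylphenyl gives a number 3 percentage points higher from compound 1 to compound 3 (within the scatter), so among these three compounds only cyclopropyl stands apart. No evidence at hand accounts for the difference between the two saturated rings.

On these data alone, whether the number follows ring size remains open, with cyclopentyl the obvious intermediate case. Also open, as far as these compounds go, is whether an open-chain hexyl group, or an amine on the cyclohexyl, would keep the number of compound 3.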